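This account rests on a few compounds, and the source may have more. Where it says the series, first, only, none or still open, it means among the compounds named here.

Measured in an assay on isolated protein (Cavia porcellus) with Sigma non-opioid intracellular receptor 1 (Homo sapiens) as the target, read by radioligand binding; a higher number here means a weaker inhibitor, a lower number a stronger inhibitor:
compound 1 `CN(C)CCCCCCCCCCOc1ccc2oc(-c3ccccc3)cc(=O)c2c1`: 341 nM
compound 2 `O=c1cc(-c2cccnc2)oc2ccc(OCCCCCCN3CCC(O)CC3)cc12`: 210 nM
compound 3 `O=c1cc(-c2ccc(F)cc2)oc2ccc(OCCCCCCN3CCC(O)CC3)cc12`: 132 nM

Compound 3 sits at the low end of the three numbers in this assay; its gap to compound 2 lies within the scatter, its gap to compound 1 beyond it. Compound 4 `O=c1cc(C2CCCCC2)oc2ccc(OCCCCCCN3CCC(O)CC3)cc12` is compound 3 with cyclohexyl in place of 4-fluorophenyl on an aromatic carbon. Going by the values given here, the only one-place step measured, a 1.6-fold lower number from compound 2 to compound 3 (0.20 log units; within the scatter), exchanges one aromatic ring for another and stays within the scatter, so it bears only loosely on a change to a non-aromatic ring; no measured pair covers that exchange directly. A modest step is therefore expected, with the number for compound 4 more likely to rise than to fall. Compound 4 is estimated at 250 nM, range 90 nM to 700 nM, which means an expected 1.9-fold higher number from compound 3 to compound 4 (0.28 log units; within the scatter).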

Compound 4, half-maximal inhibitory concentration: 46 nM
Compound 4: middle estimate off by 5.4-fold (0.74 log units), on the high side; the whole stated range lies above it.
By their numbers in this assay, from the lowest: compound 4; then compounds 3, 2 and 1 (each within the scatter of the next, the first and the last beyond it).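

At this position, on an aromatic carbon next to the ring oxygen, this assay shows a 2.9-fold lower number from compound 3 to compound 4 (0.46 log units; beyond the scatter) and a 4.6-fold lower number from compound 2 to compound 4 (0.66 log units; beyond the scatter) when cyclohexyl enters. Both steps lie beyond the scatter, whereas the exchange of one aromatic ring for another gave a 1.6-fold lower number from compound 2 to compound 3 (0.20 log units; within the scatter) and stayed within it, so a non-aromatic ring here is not merely accepted but gives the lowest number of the series. Nothing at hand gives a reason for this drop.

Open, on these data alone, is whether cyclopentyl or an open-chain tert-butyl group at this position lowers the number further. Also open, as far as these compounds go, is whether a piperidine ring here keeps the gain.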